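Replacing Cyclopropylamino with Pyrrolidin-1-yl on the Carbonyl Carbon

This account rests on a few compounds, and the source may have more. Where it says the series, first, only, none or still open, it means among the compounds named here.

In a functional assay on A549 cells (Homo sapiens) for cytotoxicity, read by sulforhodamine B assay, with a stated time of 72 h (on this read-out lower numbers stand for stronger inhibition and higher numbers for weaker inhibition), compound 1 (`Nc1sc(-c2ccc(Cl)cc2)c(-c2ccc(Cl)cc2)c1C(=O)N1CCCC1`) gives 890 nM. In this assay compound 2 (`Nc1sc(-c2ccc(Br)cc2)c(-c2ccc(Cl)cc2)c1C(=O)NC1CC1`) gives > 50000 nM, and this value is a limit of the assay and not a number. Compound 3 (`Nc1sc(-c2ccc(Br)cc2)c(-c2ccc(Cl)cc2)c1C(=O)N1CCCC1`) keeps everything in compound 2 except one group: pyrrolidin-1-yl in place of cyclopropylamino on a carbonyl carbon. In words, pyrrolidin-1-yl stands in place of cyclopropylamino on a carbonyl carbon. Among the compounds with values here, no measured pair isolates this change, so the expectation rests on compound 1, which also carries pyrrolidin-1-yl on that carbonyl carbon and gives 890 nM. A large step toward stronger inhibition in this assay is therefore expected, well beyond the scatter. The expected size of this change is an at least 50-fold lower number from compound 2 to compound 3 (1.69 log units; beyond the scatter). The estimated value for compound 3 is 1000 nM, with an expected range from 300 nM to 4000 nM.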

Compound 3, half-maximal inhibitory concentration: 7460 nM
Beside the measured number, compound 3's estimate is 7.5-fold (0.87 log units) below it, and the stated range ends below it.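

In this assay, within the data shown here, the first direct comparison at this carbonyl carbon shows that pyrrolidin-1-yl in place of cyclopropylamino gives an at least 6.7-fold lower number from compound 2 to compound 3 (0.82 log units; beyond the scatter). The reading for compound 2 is a limit of the assay and not a number, so this step gives only a minimum size: the limit of > 50000 nM in this assay, at which 1 of the 3 values shown sits. With pyrrolidin-1-yl held in place, the halogen also matters, as bromo in place of chloro on an aromatic carbon gives an 8.4-fold higher number from compound 1 to compound 3 (0.92 log units; beyond the scatter), a change beyond the scatter that the earlier values could not isolate.

The compounds shown leave open how far the step at the carbonyl carbon depends on the halogen present on the aromatic carbon. They also leave open how a piperidin-1-yl, morpholin-4-yl or dimethylamino group would read on that carbonyl carbon, and how fluoro would read in place of bromo.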